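Compound 3 to compound 4: swapping anilino for 3-acetylphenyl

The compounds below may be only part of what the source reports. "The series", "measured", "known", "first", "only" and "open" are said of these compounds alone.

In a functional assay on HepG2 cells (Homo sapiens) for cytotoxicity, read by sulforhodamine B assay, with a stated time of 24 h (on this read-out lower numbers stand for stronger inhibition and higher numbers for weaker inhibition), compound 1 `Cc1ccc(/N=C2\C(=O)Nc3ccc(S(=O)(=O)N4CCOCC4)cc32)cc1` gives 12800 nM and compound 2 `O=C1Nc2ccc(S(=O)(=O)N3CCOCC3)cc2/C1=N/NC(=O)c1ccccc1` gives 18100 nM while compound 3 `O=C1Nc2ccc(S(=O)(=O)N3CCOCC3)cc2/C1=N/Nc1ccccc1` gives 15600 nM on the same read-out. Compound 3 lies within the scatter of both other compounds, so no order can be drawn among the three.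

The step to compound 4 `CC(=O)c1cccc(/N=C2\C(=O)Nc3ccc(S(=O)(=O)N4CCOCC4)cc32)c1` is 3-acetylphenyl in place of anilino on a double-bonded nitrogen and amounts to 3-acetylphenyl in place of anilino on a double-bonded nitrogen. Within the data shown here, three measured steps bear on it. Changes at this same place gave a 1.2-fold higher number from compound 1 to compound 3 (0.09 log units; within the scatter) and a 1.4-fold higher number from compound 1 to compound 2 (0.15 log units; within the scatter) on the way from the 4-methylphenyl group, and the remaining pair gave a 1.2-fold lower number from compound 2 to compound 3 (0.06 log units; within the scatter) as its step. All three stay within the scatter.

Among the measured compounds shown here, no measured compound carries an acetyl group, so these steps give no direct reading on it. Compound 4 resembles compound 1 at 12800 nM in having a substituted phenyl group on the double-bonded nitrogen, which makes that value the closest guide. In this assay no step beyond the scatter is expected, and the estimated step is a 1.2-fold lower number from compound 3 to compound 4 (0.06 log units; within the scatter) with no firm direction. For compound 4 the estimate is 13500 nM with an expected range from 6500 nM to 27000 nM on this read-out.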

Compound 4, half-maximal inhibitory concentration: 28600 nM
For compound 4 the middle estimate is 2.1-fold (0.33 log units) below the measured one, outside the stated range (above it).
By their numbers in this assay, from the lowest: compounds 1, 3, 2 and 4 (each within the scatter of the next, the first and the last beyond it).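

In this assay the place on the double-bonded nitrogen gives its first step beyond the scatter with a 2.2-fold higher number from compound 1 to compound 4 (0.35 log units; beyond the scatter) as a modest separation of the 3-acetylphenyl group from the 4-methylphenyl group. The other two steps do not extend this separation: a 1.8-fold higher number from compound 3 to compound 4 (0.26 log units; within the scatter) and a 1.6-fold higher number from compound 2 to compound 4 (0.20 log units; within the scatter) both stay within the scatter, so anilino and benzamido cannot be ranked against 3-acetylphenyl, and the pattern rests on compound 1 and compound 4 alone. The compounds shown offer no measurement that accounts for the step from the 4-methylphenyl group to the 3-acetylphenyl group.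

Compound 1 and compound 4 differ in both the substituent on the phenyl ring and its place on that ring, so the step cannot be assigned to the acetyl group itself or to where it sits. From the compounds shown here alone, it also remains open whether an amine or a carboxylic acid on that phenyl ring would stay within the scatter of compound 1 or separate from it as the 3-acetylphenyl group does.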